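A few compounds are considered here, and "the series" means these few. Any claim that something is new, unique, unknown or untested is made for them only; others in the source may bear on it.

Measured in a functional assay on J774 cells (Mus musculus) for cytotoxicity, read by resazurin assay; on this read-out higher numbers stand for weaker inhibition and lower numbers for stronger inhibition:
Compound 1 `OCCCCCC(O)c1ccc(-c2ccc(F)cc2F)cc1`: 8000 nM
Compound 2 `Cc1cccc(-c2ccc(C(O)CCCCCO)cc2)c1`: > 100000 nM, a limit and not a number
Compound 3 `OCCCCCC(O)c1ccc(-c2ccc(O)cc2)cc1`: 15000 nM

Compound 2 has no number in this assay, only a limit, and it stands alone there: the limit of > 100000 nM in this assay, at which 1 of the 3 values shown sits. The unmeasured compound 4 `OCCCCCC(O)c1ccc(-c2ccc(Cl)cc2)cc1` has 4-chlorophenyl in place of 3-methylphenyl on an aromatic carbon, para to a group of 8 heavy atoms: 4-chlorophenyl in place of 3-methylphenyl on an aromatic carbon. Within the data shown here, one measured step bears directly on this change, since the same group leaves from the same place when 4-hydroxyphenyl enters: an at least 6.6-fold lower number from compound 2 to compound 3 (0.82 log units; beyond the scatter). That step is a bound and not an exact size, as it starts from a limit. Compound 2 also differs from compound 1 in this ring, and compound 1 gives a number too, 8000 nM. A lower number in this assay is therefore expected, of about the size of that one measured step. The estimated step is an at least 6.6-fold lower number from compound 2 to compound 4 (0.82 log units; beyond the scatter). For compound 4 the expected value is 15000 nM, with an estimated range of 5000 nM to 50000 nM.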

Compound 4, half-maximal inhibitory concentration: 17000 nM
Compound 4: middle estimate off by 1.1-fold (0.05 log units), on the low side; the range from low to high includes it.
By their numbers in this assay, from the lowest: compounds 1, 3 and 4 (each within the scatter of the next, the first and the last beyond it). At a limit, above all of these: compound 2.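

In this assay, 4-chlorophenyl in place of 3-methylphenyl on an aromatic carbon also brings the number down (an at least 5.8-fold lower number from compound 2 to compound 4 (0.76 log units; beyond the scatter)), so the step seen with 4-hydroxyphenyl is no longer a single case at this place. The two entering groups cannot be told apart, since chloro in place of hydroxy stays within the scatter (a 1.1-fold higher number from compound 3 to compound 4 (0.05 log units; within the scatter)), and in this small set compound 2, with 3-methylphenyl, stands apart from compound 3 and compound 4. Compound 2 still has a limit and not a number (> 100000 nM), so the true size of both steps from it remains a bound.

Going by these compounds, whether a 4-methylphenyl or a 3-chlorophenyl group would read like compound 2 or like compound 4 stays open. So does the reading for a 4-aminophenyl or a 4-carboxyphenyl group at the same place.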